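Working notes: 4-methylphenyl to 4-ethylphenyl

A few compounds are considered here, and "the series" means these few. Any claim that something is new, unique, unknown or untested is made for them only; others in the source may bear on it.

Measured in a functional assay on HUVEC cells (Homo sapiens); a lower number here means that less compound is needed, a higher number that more compound is needed for the effect:
Compound 1 `CCC1=C(OC)C(CC)(CC)C(=O)C(C(=O)/C=C/c2ccccc2)=C1O`: < 4 ug/mL (a limit)
Compound 2 `CCC1=C(OC)C(CC)(CC)C(=O)C(C(=O)/C=C/c2ccc(C)cc2)=C1O`: < 4 ug/mL (a limit)

Compound 2 is known only as the limit < 4 ug/mL. For the measured compounds named here, the series so far offers (the limit of < 4 ug/mL in this assay, at which 2 of the 2 values shown sit). Compound 3 `CCC1=C(OC)C(CC)(CC)C(=O)C(C(=O)/C=C/c2ccc(CC)cc2)=C1O` changes methyl to ethyl: methyl in place of hydrogen on a saturated chain carbon bound to an aromatic carbon. Going by the values given here, the one measured step bearing on this is a step that the two limits leave unreadable from compound 1 to compound 2, also methyl in place of hydrogen, there on an aromatic carbon. It gives no size or direction to carry over, so no change beyond the scatter is expected in this assay. The expected step is a step that the limit leaves unreadable from compound 2 to compound 3. The estimated value of compound 3 is 2.5 ug/mL, with an expected range of 0.8 ug/mL to 6 ug/mL.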

Compound 3, concentration for half-maximal effect: < 4 ug/mL
Compound 3 gave a limit, no number; the forecaster's own chance of this, stated with the estimate: 65%; the middle value is on the limit's open side.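

No step can be read among compound 1, compound 2 and compound 3, as each result is a limit and not a number: the limit of < 4 ug/mL in this assay, at which 3 of the 3 values shown sit.

The compounds shown leave open whether the 4-methylphenyl and 4-ethylphenyl groups differ at all in effect.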